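Sulfonamide series: amine-side variation, outlook for compound 4

The source may report more compounds than this note shows. Statements on the series, on what has been measured and on what is new or still open speak of the compounds shown alone.

Compound 1 `O=S(=O)(NCCCNCc1ccc(Cl)cc1)c1cc(C(F)(F)F)cc(C(F)(F)F)c1` gives 3000 nM in a functional assay on ASPC1 cells (Homo sapiens) for inhibition, read by MTT assay, with a stated time of 72 h; a higher number here means a weaker inhibitor of growth, a lower number a stronger inhibitor of growth.
Compound 2 `COc1cccc(CNCCCNS(=O)(=O)c2cc(C(F)(F)F)cc(C(F)(F)F)c2)c1` gives 3800 nM in this assay.
Compound 3 `O=S(=O)(NCCCNCc1ccccc1Cl)c1cc(C(F)(F)F)cc(C(F)(F)F)c1` gives 13000 nM in this assay.

Compound 3 stands highest of the three in this assay: a 4.3-fold higher number from compound 1 to compound 3 (0.64 log units; beyond the scatter) and a 3.4-fold higher number from compound 2 to compound 3 (0.53 log units; beyond the scatter), both beyond the scatter, while a 1.3-fold higher number from compound 1 to compound 2 (0.10 log units; within the scatter) stays within it. The shared core of compound 3 is kept throughout; only the group on the chain carbon varies.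

Compound 4 `CN(CCCNS(=O)(=O)c1cc(C(F)(F)F)cc(C(F)(F)F)c1)Cc1ccccc1` is not yet measured. The change is benzyl(methyl)amino in place of (2-chlorobenzyl)amino on a saturated chain carbon, three bonds along the chain from a sulfonamide nitrogen. For the measured compounds named here, two measured steps bear on it indirectly: moving from 4-chlorophenyl or 3-methoxyphenyl to 2-chlorophenyl raised the number modestly, so removing the 2-chloro is expected to bring compound 4 back toward compound 1 and compound 2. Going by the values given here, no measured pair shows what exchanging the amine hydrogen for a methyl does; that part is unconstrained and widens the range. Compound 4 is therefore expected at 5000 nM in this assay, within 1500 nM to 16000 nM, which would mean an estimated 2.6-fold lower number from compound 3 to compound 4 (0.41 log units; beyond the scatter).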

Compound 4, concentration for 50% growth inhibition: 51000 nM
Compound 4: middle estimate off by 10-fold (1.01 log units), on the low side; measured number outside the range, above it.
By their numbers in this assay, from the lowest: compounds 1 and 2 (each within the scatter of the next); then compound 3; then compound 4.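

In this assay, the benzyl(methyl)amino group stands apart from all three benzylamino groups at this position: a 3.9-fold higher number from compound 3 to compound 4 (0.59 log units; beyond the scatter), a 13-fold higher number from compound 2 to compound 4 (1.13 log units; beyond the scatter) and a 17-fold higher number from compound 1 to compound 4 (1.23 log units; beyond the scatter), each beyond the scatter. The two large steps exceed any step among the ring-substituted groups, so changes at this site are not limited to the modest differences seen earlier. Each step combines two differences, a methyl on the amine nitrogen, leaving 0 hydrogen-bond donors in the entering group against 1, and an unsubstituted phenyl ring, and no available evidence accounts for the rise in the number.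

A plain benzylamino group, carrying neither the methyl nor a ring substituent, would separate these two differences. Also open, going by these compounds, is how a larger group on that nitrogen, such as ethyl, or a longer chain would read.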